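Swapping the Ester Group of Compound 1

A few compounds are considered here, and "the series" means these few. Any claim that something is new, unique, unknown or untested is made for them only; others in the source may bear on it.

Measured compounds:
compound 1, `CC1=NC(C)=C([N+](=O)[O-])C(c2ccccn2)/C1=C(\O)OC1CCCC1`: 19800 nM
compound 2, `CC1=NC(C)=C([N+](=O)[O-])C(c2ccncc2)/C1=C(\O)OC1CCCC1`: 4250 nM

In a functional assay (cardiac atrium) for agonist activity, with Cavia porcellus as the target (a lower number here means that less compound is needed, a higher number that more compound is needed for the effect), compound 1 gives 19800 nM, the highest of the two numbers. Its nearest neighbour is compound 2, which gives 4250 nM. That step amounts to a 4.7-fold lower number from compound 1 to compound 2 (0.67 log units; beyond the scatter).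

Compound 3, `COCCO/C(O)=C1\C(C)=NC(C)=C([N+](=O)[O-])C1c1ccccn1`, differs from compound 1 by 2-methoxyethyl in place of cyclopentyl on an oxygen on an unsaturated carbon. Among the compounds with values here, the one measured step, a 4.7-fold lower number from compound 1 to compound 2 (0.67 log units; beyond the scatter), changes the ring on the saturated carbon, not the oxygen substituent, so it does not bear on this change. With no guide, no direction beyond the scatter is expected. Compound 3 is therefore estimated at 20000 nM, between 5000 nM and 80000 nM. This expected step from compound 1 is a 1.0-fold higher number from compound 1 to compound 3 (0.00 log units; within the scatter).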

Compound 3, half-maximal effective concentration: 9700 nM
The estimate for compound 3 lay 2.1-fold (0.31 log units) above the measured number, and the stated range covers the measured number.
By their numbers in this assay, from the lowest: compound 2; then compound 3; then compound 1.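

The oxygen substituent had not been varied before, and replacing cyclopentyl with 2-methoxyethyl at this position gives a 2.0-fold lower number from compound 1 to compound 3 (0.31 log units; beyond the scatter) in this assay. The position therefore responds to change, and the carbon-only ring is not needed to keep the effect. Nothing available explains this step.

On these data alone, it remains open whether the lower number follows from the ether oxygen or from the loss of the ring, which a plain n-butyl group could help separate. As far as these compounds go, whether the same change holds alongside pyridin-4-yl also remains open.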